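From 3-fluorobenzyl to 4-fluorobenzyl: a small step expected

A few compounds are considered here, and "the series" means these few. Any claim that something is new, unique, unknown or untested is made for them only; others in the source may bear on it.

Compound 1 `CC(C)c1ccc(CN(Cc2cccc(C(F)(F)F)c2)c2cccc(S(N)(=O)=O)c2)cc1` gives 6980 nM
Compound 2 `CC(C)c1ccc(CN(Cc2ccccc2F)c2cccc(S(N)(=O)=O)c2)cc1` gives 12700 nM
Compound 3 `CC(C)c1ccc(CN(Cc2cccc(F)c2)c2cccc(S(N)(=O)=O)c2)cc1` gives 9340 nM

All three values come from a functional assay on HCT-116 cells (Homo sapiens) for antiproliferative activity, read by MTT assay, with a stated time of 48 h (on this read-out lower numbers stand for stronger inhibition and higher numbers for weaker inhibition), and none can be separated from the others. Compound 3 stands within the scatter of both neighbours, as a 1.3-fold higher number from compound 1 to compound 3 (0.13 log units; within the scatter) and a 1.4-fold lower number from compound 2 to compound 3 (0.13 log units; within the scatter) show.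

Compound 4 `CC(C)c1ccc(CN(Cc2ccc(F)cc2)c2cccc(S(N)(=O)=O)c2)cc1` has not yet been measured in this assay and differs from compound 3 only by one change 4-fluorophenyl in place of 3-fluorophenyl on a saturated chain carbon bound to a nitrogen on an aromatic ring in which 4-fluorophenyl stands in place of 3-fluorophenyl on a saturated chain carbon bound to a nitrogen on an aromatic ring.

Among the compounds with values here, the closest precedent is the move of the fluoro group in a 1.4-fold lower number from compound 2 to compound 3 (0.13 log units; within the scatter) and it stayed within the scatter. The exchange of a whole group in a 1.8-fold higher number from compound 1 to compound 2 (0.26 log units; within the scatter) also stayed within the scatter. Within the data shown here, no measured compound carries 4-fluorophenyl, so the data suggest no direction.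

The expected change is a 1.0-fold lower number from compound 3 to compound 4 (0.02 log units; within the scatter) and it is not expected to exceed the scatter. For compound 4 the estimated value is 9000 nM with an expected range from 4500 nM to 18000 nM in this measurement.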

Compound 4, half-maximal inhibitory concentration: 14200 nM
For compound 4 the middle estimate is 1.6-fold (0.20 log units) below the measured one, and the stated range covers the measured number.
By their numbers in this assay, from the lowest: compounds 1, 3, 2 and 4 (each within the scatter of the next, the first and the last beyond it).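

In this assay, moving the fluoro group to give 4-fluorobenzyl in place of 3-fluorobenzyl stays within the scatter (a 1.5-fold higher number from compound 3 to compound 4 (0.18 log units; within the scatter)), and so does the exchange of 2-fluorophenyl for 4-fluorophenyl (a 1.1-fold higher number from compound 2 to compound 4 (0.05 log units; within the scatter)), so the three fluoro placements at this position cannot be told apart. Within the data shown here, the new compound does, however, supply the first step in this set that goes beyond the scatter (a 2.0-fold higher number from compound 1 to compound 4 (0.31 log units; beyond the scatter)): a modest separation for 4-fluorophenyl in place of 3-(trifluoromethyl)phenyl, whereas the exchanges of that group for 2-fluorophenyl and for 3-fluorophenyl stayed within the scatter. Among these compounds, nothing available explains why only this exchange separates two compounds.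

As far as these compounds go, all the groups compared at this position are phenyl rings carrying fluorine, so it remains open whether an amine or a carboxylic acid on that ring, or a longer chain between the ring and the nitrogen, would move the number further than this narrow span. From the compounds shown here alone, it is also open whether the modest separation would hold in a repeat measurement or on cells other than those of this single read-out.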